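Trifluoromethyl on the aromatic ring: expectation for compound 3

The source may report more compounds than this note shows. Statements on the series, on what has been measured and on what is new or still open speak of the compounds shown alone.

Compound 1 `O=C1OC[C@H](Cc2ccccc2)[C@H]1Cc1ccccc1` is the reference of this pair. In a functional assay on HL-60 cells (Homo sapiens) for cytotoxicity, read by WST assay, with a stated time of 48 h (on this read-out lower numbers stand for an effect already at smaller amounts and higher numbers for an effect only at larger amounts of compound), compound 1 gives 77000 nM. Within the data shown here, its only measured neighbour is compound 2 `Cc1ccccc1C[C@H]1C(=O)OC[C@@H]1Cc1ccccc1`, which in this assay gives 57000 nM; the step of a 1.4-fold lower number from compound 1 to compound 2 (0.13 log units; within the scatter), methyl in place of hydrogen on an aromatic carbon, keeps both compounds on the same footing, and no other measured step exists.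

Compound 3 `O=C1OC[C@H](Cc2ccccc2)[C@H]1Cc1cccc(C(F)(F)F)c1` differs from compound 1 by trifluoromethyl in place of hydrogen on an aromatic carbon. Among the measured compounds shown here, the one step that bears on it is the aromatic substitution from compound 1 to compound 2, which stayed within the scatter; a single substituent on this ring has therefore not yet moved the number in this assay. On that basis no step beyond the scatter is expected for compound 3, and a 1.3-fold lower number from compound 1 to compound 3 (0.11 log units; within the scatter) is the estimated change. Compound 3 is expected to give 60000 nM in this assay, within 25000 nM to 150000 nM.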

Compound 3, half-maximal effective concentration: 34000 nM
Beside the measured number, compound 3's estimate is 1.8-fold (0.25 log units) above it; the measured number falls inside the stated range.
By their numbers in this assay, from the lowest: compounds 3, 2 and 1 (each within the scatter of the next, the first and the last beyond it).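

In this assay, trifluoromethyl in place of hydrogen gives a 2.3-fold lower number from compound 1 to compound 3 (0.36 log units; beyond the scatter), so a substituent on an aromatic carbon of this core can move the number beyond the scatter, though only modestly. The earlier substitution did not show this: a 1.4-fold lower number from compound 1 to compound 2 (0.13 log units; within the scatter) leaves the two compounds on the same footing. Nothing measured here accounts for the shift seen with trifluoromethyl.

Because compound 3 carries a different group at a different place from compound 2, the compounds shown do not separate the effect of the group from that of its position on the ring. A methyl, a methoxy group or a chlorine atom on the same aromatic carbon as the trifluoromethyl would help separate them, and the same holds for trifluoromethyl on the other aromatic ring.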